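A Smaller Ring on the Amide Arm

The compounds below may be only part of what the source reports. "The series", "measured", "known", "first", "only" and "open" are said of these compounds alone.

Measured in an assay on blood for inhibition of C-X-C chemokine receptor type 3 (Homo sapiens), with a stated time of 30 min (on this read-out higher numbers stand for weaker inhibition and lower numbers for stronger inhibition), so far:
- compound 1 `C[C@@H]1CN(c2scnc2-c2nc3ccccc3[nH]2)CCN1C(=O)Cn1cnc2cccnc21` gives 554 nM
- compound 2 `CCOc1ncc(-c2nc(C(F)(F)F)sc2N2CCN(C(=O)Cn3cnc4ccccc43)[C@H](C)C2)cn1` gives 192 nM

Compound 2 therefore stands at the lower of the two numbers, and its gap to compound 1 lies beyond the usual scatter of this assay; these two compounds differ in more than one place, so no single change accounts for that gap.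

Compound 3 `CCOc1ncc(-c2nc(C(F)(F)F)sc2N2CCN(C(=O)Cn3nccc3C)[C@H](C)C2)cn1` keeps the core of compound 2 and alters only the group on the amide arm: 5-methyl-1H-pyrazol-1-yl in place of 1H-benzimidazol-1-yl on a saturated chain carbon bound to a carbonyl carbon. Among the measured compounds shown here, no measured pair in this set isolates such a change, so its effect is unknown. A smaller group replacing a larger one is expected to cost some inhibition, and the step from compound 2 is estimated as a 2.2-fold higher number from compound 2 to compound 3 (0.34 log units; beyond the scatter), a modest weakening. Compound 3 is thus expected to give about 420 nM in this assay, within a range from 120 nM to 1500 nM.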

Compound 3, half-maximal inhibitory concentration: 289 nM
Beside the measured number, compound 3's estimate is 1.5-fold (0.16 log units) above it; the measured number falls inside the stated range.
By their numbers in this assay, from the lowest: compounds 2, 3 and 1 (each within the scatter of the next, the first and the last beyond it).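

Among the compounds shown here, replacing 1H-benzimidazol-1-yl with 5-methyl-1H-pyrazol-1-yl on a saturated chain carbon bound to a carbonyl carbon gives, in this assay, a 1.5-fold higher number from compound 2 to compound 3 (0.18 log units; within the scatter) and is the first change here that can be read in one place. The two compounds cannot be told apart, so at this place the six-membered aromatic ring of carbon only can go, leaving a single five-membered aromatic ring, without a loss that this assay can resolve. Nothing measured here accounts for this result.

Still open, going by these compounds, is whether the methyl on the pyrazole matters, which a plain 1H-pyrazol-1-yl group would test. It is also unknown whether this place would accept something other than an aromatic ring, such as a simple amine or a carboxylic acid.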